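The compounds below may be only part of what the source reports. "The series", "measured", "known", "first", "only" and "open" are said of these compounds alone.

Compound 1 `CCOC(=O)c1c(-c2c(Cl)c3cc(C)ccc3oc2=O)nn(-c2cccc(C)c2)c1C(=O)OCC` and compound 2 `CCOC(=O)c1c(-c2c(Cl)c3cc(C)ccc3oc2=O)nn(-c2cccc(Cl)c2)c1C(=O)OCC` share one core, while compound 3 `CCOC(=O)c1c(-c2cc3ccc(OCC=C(C)C)cc3oc2=O)nn(-c2cccc(C)c2)c1C(=O)OCC` and compound 4 `CCOC(=O)c1c(-c2cc3ccc(OCC=C(C)C)cc3oc2=O)nn(-c2cccc(Cl)c2)c1C(=O)OCC` share another; how the two cores differ is not broken down here. In a functional assay on A549 cells (Homo sapiens) for cytotoxicity, read by MTT assay, with a stated time of 48 h (a higher number here means a weaker inhibitor, a lower number a stronger inhibitor), compound 1 gives 115000 nM, compound 2 gives 128000 nM, and compound 3 gives 178000 nM. The change from compound 1 to compound 2 is chloro in place of methyl on an aromatic carbon, and it made a step of a 1.1-fold higher number from compound 1 to compound 2 (0.05 log units; within the scatter). The change from compound 3 to compound 4 is the same change, (chloro in place of methyl on an aromatic carbon), made on the other core. Because a 1.1-fold higher number from compound 1 to compound 2 (0.05 log units; within the scatter) was within the scatter, the step expected from compound 3 to compound 4 in this assay is about as small, a 1.1-fold higher number from compound 3 to compound 4 (0.03 log units; within the scatter). Compound 4 is therefore estimated at 190000 nM, most likely between 100000 nM and 350000 nM.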

Compound 4, half-maximal inhibitory concentration: 163000 nM
Compound 4: middle estimate off by 1.2-fold (0.07 log units), on the high side, and the stated range covers the measured number.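

In this assay, putting chloro in place of methyl on the second core gives a 1.1-fold lower number from compound 3 to compound 4 (0.04 log units; within the scatter), so this swap of 3-methylphenyl to 3-chlorophenyl makes no readable difference there. The same holds on the first core, and the two steps agree: the same change on two cores in this assay, a 1.1-fold higher number (0.05 log units; within the scatter) from compound 1 to compound 2 and a 1.1-fold lower number (0.04 log units; within the scatter) from compound 3 to compound 4, 1.2-fold (0.08 log units) apart, within the scatter of two such steps This shows that a swap with no readable effect stayed that way on both cores, but it does not show that a change with a real effect would carry from one core to the other.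

Still open, from the compounds shown here alone, is whether a different group on the same aromatic carbon, such as an amine or a carboxylic acid, would give a step beyond the scatter. Going by these compounds, whether such a step would then carry across both cores is also open.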